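Butylamino to Pyrrolidin-1-yl on a Shared Core

This account rests on a few compounds, and the source may have more. Where it says the series, first, only, none or still open, it means among the compounds named here.

Three compounds share one core and differ only in what sits on the amide-type nitrogen: compound 1 (`CCCCc1oc2ccccc2c1C(=O)c1ccc(OCC(N)=O)cc1`), compound 2 (`CCCCc1oc2ccccc2c1C(=O)c1ccc(OCC(=O)NC(C)C)cc1`) and compound 3 (`CCCCNC(=O)COc1ccc(C(=O)c2c(CCCC)oc3ccccc23)cc1`). In a functional assay on U-937 cells (Homo sapiens) for antiproliferative activity, read by MTT assay, with a stated time of 24 h (a lower number here means a stronger inhibitor, a higher number a weaker inhibitor), compound 1 gives 42200 nM, compound 2 gives 17500 nM and compound 3 gives 22800 nM. Compound 3 therefore stands within the scatter of both others: a 1.9-fold lower number from compound 1 to compound 3 (0.27 log units; within the scatter), and a 1.3-fold higher number from compound 2 to compound 3 (0.11 log units; within the scatter). Within the data shown here, the one step beyond the scatter is modest: a 2.4-fold lower number from compound 1 to compound 2 (0.38 log units; beyond the scatter).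

Compound 4 (`CCCCc1oc2ccccc2c1C(=O)c1ccc(OCC(=O)N2CCCC2)cc1`) has pyrrolidin-1-yl in place of butylamino on a carbonyl carbon. The three measured compounds all keep a hydrogen on that nitrogen and none has a ring there, so this exact kind of change has not been tested. The nearest guide is the swap of one group for another on the nitrogen in compound 3, a 1.3-fold higher number from compound 2 to compound 3 (0.11 log units; within the scatter), which stayed within the scatter. Even replacing the hydrogen of compound 1 moved the number only modestly, as in a 2.4-fold lower number from compound 1 to compound 2 (0.38 log units; beyond the scatter). A small shift in either direction is therefore expected in this assay, and the estimated change is a 1.1-fold higher number from compound 3 to compound 4 (0.02 log units; within the scatter). For compound 4 the estimated value is 24000 nM, with an expected range of 11000 nM to 50000 nM.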

Compound 4, half-maximal inhibitory concentration: 32500 nM
Estimate against measurement, compound 4: 1.4-fold (0.13 log units) below; low and high end bracket the measured number.
By their numbers in this assay, from the lowest: compounds 2, 3, 4 and 1 (each within the scatter of the next, the first and the last beyond it).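

In this assay, among these compounds, the pyrrolidin-1-yl group gives the first compound here with a ring on this nitrogen and without the amide hydrogen, yet every new step stays within the scatter: a 1.4-fold higher number from compound 3 to compound 4 (0.15 log units; within the scatter), a 1.9-fold higher number from compound 2 to compound 4 (0.27 log units; within the scatter) and a 1.3-fold lower number from compound 1 to compound 4 (0.11 log units; within the scatter). The earlier compounds shown here all kept a hydrogen-bond donor on this nitrogen, so they could not show that a number in this range also occurs with none there, as compound 4 now does. No measurement shown here gives a reason for these numbers.

Both features arrive together in this single change, so the compounds shown leave open how the ring and the loss of the amide hydrogen each contribute, a question that a diethylamino group, with no ring and no amide hydrogen, could help to separate. Also open, on these data alone, is whether a piperidin-1-yl or morpholin-4-yl group on the same carbonyl carbon would stay within the scatter of compound 4 or produce a step beyond it.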